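The source may hold more compounds than are shown below. What is called first, only, known or untested is meant among the compounds shown, and "the series" means these compounds.

Among the compounds with values here, in a functional assay on DU-145 cells (Homo sapiens) for cytotoxicity, read by MTT assay (on this read-out lower numbers stand for stronger inhibition and higher numbers for weaker inhibition), compound 1 (`COc1ccc2cc([C@H](C)c3nnc(SCc4ccc(C)cc4)n3-c3ccc(F)cc3)ccc2c1`) gives 44300 nM and stands as the higher of the two numbers so far, while compound 2 (`COc1ccc2cc([C@H](C)c3nnc(SCc4ccc(C)cc4)n3-c3ccc(Cl)cc3)ccc2c1`) gives 18800 nM there. Compound 3 (`COc1ccc2cc([C@H](C)c3nnc(SCc4c(Cl)cccc4Cl)n3-c3ccc(F)cc3)ccc2c1`) has not yet been measured. It differs from compound 1 at one place, with 2,6-dichlorophenyl in place of 4-methylphenyl on a saturated chain carbon bound to a sulfur. Within the data shown here, the only measured step, a 2.4-fold lower number from compound 1 to compound 2 (0.37 log units; beyond the scatter) for chloro in place of fluoro on an aromatic carbon, falls at a different place, so it offers a rough scale and no firm direction. Among the measured compounds shown here, no measured compound shows what the 4-methylbenzyl exchange itself does. A similarly modest lowering in this assay is therefore expected, an estimated 1.8-fold lower number from compound 1 to compound 3 (0.25 log units; within the scatter) with wide uncertainty either way. For compound 3 the estimated value is 25000 nM (expected range 8000 nM to 70000 nM).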

Compound 3, half-maximal inhibitory concentration: 12300 nM
Beside the measured number, compound 3's estimate is 2.0-fold (0.31 log units) above it, and the stated range covers the measured number.
By their numbers in this assay, from the lowest: compounds 3 and 2 (each within the scatter of the next); then compound 1.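

The position on the saturated chain carbon bound to a sulfur, which the earlier pair left untouched, proves able to move the number in this assay: 2,6-dichlorophenyl in place of 4-methylphenyl gives a 3.6-fold lower number from compound 1 to compound 3 (0.56 log units; beyond the scatter) as a modest step. The aromatic carbon carrying fluoro or chloro is therefore not the only place in this series where a single exchange takes the number beyond the scatter. Nothing given here accounts for the size or the direction of this step.

The compounds shown leave open whether the two chlorines or the loss of the methyl carries the step, and whether a plain benzyl or a 4-chlorobenzyl would do the same. Also open, going by these compounds, is how an amine or a carboxylic acid on this ring would read, and whether the 2,6-dichlorobenzyl exchange would act alike on compound 2.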